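The compounds below may be only part of what the source reports. "The series", "measured", "known", "first", "only" and "open" are said of these compounds alone.

Compound 1 `Cc1ccc(-c2c(CNC(C)(C)C)c(C(=O)O)nn2-c2ccccc2)cc1` was tested in a functional assay on K562 cells (Homo sapiens) for inhibition, read by sulforhodamine B assay, with a stated time of 48 h; a higher number here means a weaker inhibitor of growth, a lower number a stronger inhibitor of growth. In this assay compound 1 gives only > 688000 nM, a limit of the assay rather than a number. Compound 2 `COc1ccc(-c2c(CNC(C)(C)C)c(C(=O)O)nn2-c2ccccc2)cc1` differs from compound 1 by methoxy in place of methyl on an aromatic carbon. In this assay compound 2 also reaches only a limit, > 659000 nM. The step that the two limits leave unreadable from compound 1 to compound 2 therefore cannot be read, since both values sit at the limit of > 688000 nM in this assay, at which 1 of the 3 values shown sits, and (the limit of > 659000 nM in this assay, at which 1 of the 3 values shown sits). Compound 3 `Cc1ccc(-c2c(CNC(C)(C)C)c(C(=O)O)nn2-c2ccc(Cl)cc2)cc1` differs from compound 1 in its core by chloro in place of hydrogen on an aromatic carbon. In this assay compound 3 again shows only a limit, > 629000 nM, recorded as the limit of > 629000 nM in this assay, at which 1 of the 3 values shown sits. Compound 4 `COc1ccc(-c2c(CNC(C)(C)C)c(C(=O)O)nn2-c2ccc(Cl)cc2)cc1` is not yet measured; it stands to compound 3 by the same change as compound 2 to compound 1, namely (methoxy in place of methyl on an aromatic carbon). For compound 4 the step that the limit leaves unreadable from compound 3 to compound 4 is expected, resting on the unreadable a step that the two limits leave unreadable from compound 1 to compound 2. The estimate for compound 4 in this assay is 700000 nM, expected between 250000 nM and 2500000 nM.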

Compound 4, concentration for 50% growth inhibition: > 605000 nM
Compound 4 ended at the assay's limit; the forecaster's own chance of this, stated with the estimate: 90%; the middle value lies beyond the limit too.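

In this assay compound 4, like compound 2 and compound 3, reaches only a limit, so neither step to compound 4 can be read. The compounds shown leave open whether methoxy in place of methyl or chloro in place of hydrogen changes growth inhibition at all.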